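A few compounds are considered here, and "the series" means these few. Any claim that something is new, unique, unknown or untested is made for them only; others in the source may bear on it.

Measured in an ADME assay for permeability, using PAMPA, with a stated time of 30 min, at pH 7.4; on this read-out lower numbers stand for lower permeability and higher numbers for higher permeability:
compound 1 `COc1ccc(F)cc1CNCCCNc1ccnc2cc(C3CCCCC3)ccc12` gives 23 10^-6 cm/s
compound 2 `COc1ccc(F)cc1CNCCCNc1ccnc2cc(CCC(C)C)ccc12` gives 23 10^-6 cm/s
compound 3 `COc1cccc(Oc2ccc3c(NCCCNCc4cc(F)ccc4OC)ccnc3c2)c1` gives 317 10^-6 cm/s

Compound 3 stands highest of the three numbers; both other compounds lie far below it. Going by the values given here, the only two measured steps that lead to compound 3 are large: a 14-fold higher number from compound 1 to compound 3 (1.14 log units; beyond the scatter) and a 14-fold higher number from compound 2 to compound 3 (1.14 log units; beyond the scatter). Between compound 1 and compound 2 there is no change at the digits printed from compound 1 to compound 2 (within the scatter), so exchanging cyclohexyl for isopentyl left the read-out where it was.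

Compound 4 `COc1ccc(F)cc1CNCCCNc1ccnc2cc(CCc3ccccc3)ccc12` differs from compound 3 in one place: phenethyl in place of 3-methoxyphenoxy on an aromatic carbon. The phenethyl group resembles the cyclohexyl of compound 1 and the isopentyl of compound 2 more closely than it does the 3-methoxyphenoxy of compound 3, and those two compounds sit together at the low end. The steps from compound 1 and compound 2 to compound 3 are the ones that bear on this change, and running a change of that kind in reverse leads one to expect a large downward step, a 7.9-fold lower number from compound 3 to compound 4 (0.90 log units; beyond the scatter), in this assay. Compound 4 is therefore estimated at 40 10^-6 cm/s, with a range from 15 10^-6 cm/s to 120 10^-6 cm/s.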

Compound 4, apparent permeability: 23 10^-6 cm/s
For compound 4 the middle estimate is 1.7-fold (0.24 log units) above the measured one; low and high end bracket the measured number.
By their numbers in this assay, from the lowest: compounds 1, 2 and 4 (each within the scatter of the next); then compound 3.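

In this assay, the phenethyl group does not keep the high number of the 3-methoxyphenoxy group, although both carry one six-membered aromatic ring of carbon only: the exchange gives a 14-fold lower number from compound 3 to compound 4 (1.14 log units; beyond the scatter) at this aromatic carbon. The ring alone therefore does not go with the high number, since compound 4 falls in with the two groups that lack such a ring, with no change at the digits printed from compound 2 to compound 4 (within the scatter) and no change at the digits printed from compound 1 to compound 4 (within the scatter). Among these four compounds only compound 3, whose group carries 2 hydrogen-bond acceptors, stands apart, and nothing available explains why.

On these data alone, what remains open is which part of the 3-methoxyphenoxy group goes with the high number, and whether a plain phenoxy or a benzyloxy would stay with compound 3 or fall with compound 4. Also open, as far as these compounds go, is how an amine or a carboxylic acid at this place would read.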